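Compound 3 and a Change Next to the Ring Sulfur

The compounds below may be only part of what the source reports. "The series", "measured", "known", "first", "only" and "open" are said of these compounds alone.

Of the compounds shown here, two sharing one core have been measured. In an assay on CHO cells for displacement of a labelled ligand from adenosine receptor A1 (Homo sapiens), read by scintillation counting, tested at 10 uM (a lower number here means less inhibition, a higher number more inhibition at the concentration tested (going by the name of the read-out)), compound 1 `CC(C)(C)Cc1c(-c2ccoc2)sc(N)c1C(=O)c1ccc(Cl)cc1` gives 1%, and compound 2 `CC(C)(C)Cc1c(/C=C/c2ccc(Cl)cc2)sc(N)c1C(=O)c1ccc(Cl)cc1` gives 1%. The single step between them, no change at the digits printed from compound 1 to compound 2 (within the scatter), left the read-out where it was, so compound 2 stands level with compound 1 at the digits shown, both at the low end of the scale. Compound 3 `Cc1ccccc1-c1sc(N)c(C(=O)c2ccc(Cl)cc2)c1CC(C)(C)C` has not yet been measured. It differs from compound 2 in one place: 2-methylphenyl in place of 2-(4-chlorophenyl)ethenyl on an aromatic carbon. For the measured compounds named here, only the step from compound 1 to compound 2 bears on this change; it exchanged one group on an aromatic carbon for another and produced no shift beyond the scatter. Compound 3 is therefore expected to show no step beyond the scatter, a number 1 percentage points higher from compound 2 to compound 3 (within the scatter). The estimate for compound 3 is 2%, expected within a range from -8% to 14%.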

Compound 3, a percentage reported as inhibition, at one concentration (the size of the read-out at that concentration, not a potency): 1%
Estimate against measurement, compound 3: 1 percentage points above; the range from low to high includes it.
By their numbers in this assay, from the lowest: compounds 1, 2 and 3 (each within the scatter of the next).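

At the aromatic carbon next to the ring sulfur, 2-methylphenyl in place of 2-(4-chlorophenyl)ethenyl gives no change at the digits printed from compound 2 to compound 3 (within the scatter) in this assay, and 2-methylphenyl in place of furan-3-yl gives no change at the digits printed from compound 1 to compound 3 (within the scatter). The earlier step had set only furan-3-yl against 2-(4-chlorophenyl)ethenyl; now a third group, one with no double bond outside aromatic rings, reads alike with them, and all three stay at the low end of the scale. No measured evidence bears on this result.

The compounds shown leave open whether any group at this carbon, such as an amine or a carboxylic acid, would lift the read-out at all. They also leave open what a change to the neopentyl group or the (4-chlorophenyl)carbonyl group would do, as both stay the same throughout.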